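Cytotoxicity notes: allyl to 4-methylphenyl on the thioamide nitrogen

The compounds below may be only part of what the source reports. "The series", "measured", "known", "first", "only" and "open" are said of these compounds alone.

Measured so far:
Compound 1, `C=CCNC(=S)N/N=C\c1ccnc2ccccc12`, in an ADME assay on RAW264.7 cells (Mus musculus) for cytotoxicity, read by MTT assay, with a stated time of 48 h; on this read-out lower numbers stand for higher toxicity in this test and higher numbers for lower toxicity in this test: 105000 nM
Compound 2, `Fc1ccc(NC(=S)N/N=C\c2ccnc3ccccc23)cc1`: 45900 nM
Compound 3, `O=[N+]([O-])c1ccc(NC(=S)N/N=C\c2ccnc3ccccc23)cc1`: 82500 nM

Among the compounds with values here, compound 1 stands highest of the three numbers; its gap to compound 3 is within the scatter, and only the step of a 2.3-fold lower number from compound 1 to compound 2 (0.36 log units; beyond the scatter) lies beyond it. Compound 4, `Cc1ccc(NC(=S)N/N=C\c2ccnc3ccccc23)cc1`, differs from compound 1 in one place: 4-methylphenyl in place of allyl on an amide-type nitrogen. The step that bears on this is a 2.3-fold lower number from compound 1 to compound 2 (0.36 log units; beyond the scatter), where 4-fluorophenyl took the place of allyl on the same nitrogen. The step of a 1.8-fold higher number from compound 2 to compound 3 (0.25 log units; within the scatter), nitro in place of fluoro, stayed within the scatter, so the substituent on the ring carried little weight there. A modest fall is therefore expected, a 1.9-fold lower number from compound 1 to compound 4 (0.28 log units; within the scatter). Compound 4 is estimated at 55000 nM, with a range from 25000 nM to 120000 nM.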

Compound 4, half-maximal cytotoxic concentration: 50500 nM
Compound 4: middle estimate off by 1.1-fold (0.04 log units), on the high side, within the range that was stated.
By their numbers in this assay, from the lowest: compounds 2, 4, 3 and 1 (each within the scatter of the next, the first and the last beyond it).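

Replacing allyl with 4-methylphenyl gives a 2.1-fold lower number from compound 1 to compound 4 (0.32 log units; beyond the scatter), so compound 4 repeats the fall seen with compound 2, while compound 3 goes against this pattern, its gap to compound 1 being within the scatter. On the aromatic ring, methyl in place of fluoro gives a 1.1-fold higher number from compound 2 to compound 4 (0.04 log units; within the scatter) and methyl in place of nitro gives a 1.6-fold lower number from compound 3 to compound 4 (0.21 log units; within the scatter), both within the scatter, so these three ring substituents are not told apart.

No supporting data bear on why the number falls. From the compounds shown here alone, whether a longer chain in place of allyl, or an amine or carboxylic acid on the aromatic ring, would shift the number remains open.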